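The source may report more compounds than this note shows. Statements on the series, on what has been measured and on what is new or still open speak of the compounds shown alone.

Measured compounds:
compound 1, `Cc1ccc(-n2cc(Cn3cc(CO)nn3)c(-c3ccccc3)n2)cc1C` — 7720 nM
compound 2, `COc1ccc(-c2nn(-c3ccccc3)cc2CO)cc1` — 8240 nM

The two measured compounds were tested in a functional assay on U-937 cells (Homo sapiens) for inhibition, read by ELISA, with stated times of 1 h and 24 h; a higher number here means a weaker inhibitor, a lower number a stronger inhibitor. Compound 1 gives 7720 nM there, and compound 2, built on a different core, gives 8240 nM. The gap between these two numbers lies within the usual scatter of such measurements, so on the numbers shown neither compound stands apart from the other, and compound 1 cannot be called the stronger of the pair.

The account follows the step from compound 1 to compound 3, `Cc1ccc(-n2cc(Cn3cc(CO)nn3)c(-c3ccccc3)n2)cc1`, which has not yet been measured. The change is small: hydrogen in place of methyl on an aromatic carbon. Among the measured compounds shown here, no pair of measured compounds differs in exactly this way. For the measured compounds named here, there is no measured step to lean on. Given that only a methyl group is removed from the ring and the rest of the molecule is unchanged, the step is expected to be small in this assay, most likely no larger than the scatter, and if anything a slight weakening.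

Compound 3 is therefore estimated at 9500 nM, with a range from 4000 nM to 22000 nM, which corresponds to an expected step of a 1.2-fold higher number from compound 1 to compound 3 (0.09 log units; within the scatter).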

Compound 3, half-maximal inhibitory concentration: 8700 nM
The estimate for compound 3 lay 1.1-fold (0.04 log units) above the measured number; low and high end bracket the measured number.
By their numbers in this assay, from the lowest: compounds 1, 2 and 3 (each within the scatter of the next).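

In this assay, among the compounds shown here, the change from 3,4-dimethylphenyl to 4-methylphenyl gives the first comparison of two measured compounds that differ in one place, and it amounts to a 1.1-fold higher number from compound 1 to compound 3 (0.05 log units; within the scatter). On this single pair, the methyl group ortho to a methyl group and meta to a large group can give way to hydrogen without a change in the number that the measurement can separate from scatter, so this methyl group is not shown to matter in this assay, although one pair cannot show more than that. No measurement available here bears on the reason for this outcome.

As far as these compounds go, it remains open whether the second methyl group of the 4-methylphenyl ring can also give way to hydrogen, and whether a different group on the same aromatic carbon, such as a methoxy group, an amine or a carboxylic acid, would produce a step beyond the scatter. As the three compounds all lie within the scatter of one another, they also leave open which part of these structures the number responds to at all.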